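Trading an amide for a urea on a shared core

A few compounds are considered here, and "the series" means these few. Any claim that something is new, unique, unknown or untested is made for them only; others in the source may bear on it.

Measured so far in a functional assay on SNB-19 cells (Homo sapiens) for inhibition, read by sulforhodamine B assay, with a stated time of 48 h; on this read-out higher numbers stand for weaker inhibition of growth and lower numbers for stronger inhibition of growth:
Compound 1, `COc1cc(-c2nn(-c3cccc(NC(=O)c4ccc(Cl)c(C(F)(F)F)c4)c3)cc2-c2ccncc2)ccc1Cl`, gives > 32500 nM.
Compound 2, `COc1cc(-c2nn(-c3cccc(NC(=O)c4cccc(C(F)(F)F)c4)c3)cc2-c2ccncc2)ccc1Cl`, gives > 50000 nM.
Compound 3, `O=C(Nc1cccc(-n2cc(-c3ccncc3)c(-c3ccc(Cl)c(O)c3)n2)c1)Nc1ccc(Cl)c(C(F)(F)F)c1`, gives 4860 nM.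

Compound 1 stands only at a limit of the assay, not at a number. Compound 2 likewise stands only at a limit. Compound 3 alone gives a measured number. The step that the two limits leave unreadable from compound 1 to compound 2 cannot be read because both of its ends sit at the limit of > 32500 nM in this assay, at which 1 of the 3 values shown sits, and (the limit of > 50000 nM in this assay, at which 1 of the 3 values shown sits).

Compound 4, `COc1cc(-c2nn(-c3cccc(NC(=O)Nc4ccc(Cl)c(Cl)c4)c3)cc2-c2ccncc2)ccc1Cl`, is not yet measured. It differs from compound 1 by (3,4-dichlorophenyl)amino in place of 4-chloro-3-(trifluoromethyl)phenyl on a carbonyl carbon. Within the data shown here, no measured step carries this same change, so its size cannot be borrowed from the data. Compound 3, which also carries an amino group on its carbonyl carbon, gives a number where compound 1 gives only a limit, yet compound 3 differs from compound 4 in more than one place, so only their two values can be compared. Compound 4 is therefore expected near 15000 nM, between 4000 nM and 50000 nM, which would be an estimated step of an at least 2.1-fold lower number from compound 1 to compound 4 (0.33 log units; beyond the scatter) in this assay.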

Compound 4, concentration for total growth inhibition: > 50000 nM
Compound 4 gave a limit, no number; the forecaster's own chance of this, stated with the estimate: 35%; middle value at least 3.3-fold (0.52 log units) from the limit.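

Compound 4 gives > 50000 nM, which is a limit and not a number. Among these compounds, compound 1, compound 2 and compound 4 all stand at limits, so no step among them can be read. Still open, from the compounds shown here alone, is whether (3,4-dichlorophenyl)amino on the carbonyl carbon changes growth inhibition at all on this shared core.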